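Cytotoxicity on HEp-2 cells: compounds 1 to 4

A few compounds are considered here, and "the series" means these few. Any claim that something is new, unique, unknown or untested is made for them only; others in the source may bear on it.

compound 1 `Cc1nnc(SCc2cc(=O)c3ccccc3o2)o1`: in a functional assay on HEp-2 cells (Homo sapiens) for cytotoxicity, read by MTT assay, with a stated time of 72 h (on this read-out higher numbers stand for weaker inhibition and lower numbers for stronger inhibition), compound 1 gives > 25000 nM, a limit of the assay.
compound 2 `O=c1cc(CSc2nc3ccccc3s2)oc2ccc(Cl)cc12`: in this assay compound 2 gives > 25000 nM, a limit of the assay.
compound 3 `Cc1nnc(SCc2cc(=O)c3cc(Cl)ccc3o2)s1`: in this assay compound 3 gives > 25000 nM, a limit of the assay.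

Every value shown sits at the limit of > 25000 nM in this assay, at which 3 of the 3 values shown sit; none is a number. Compound 3 therefore stands at the limit of this assay, and no ordering between compound 1, compound 2 and compound 3 can be read from these values.

Compound 4 `Cc1nnc(SCc2cc(=O)c3ccccc3o2)s1` differs from compound 3 in one place: hydrogen in place of chloro on an aromatic carbon. Among the compounds with values here, no step between measured compounds is known. The change is expected to bring no step beyond the scatter in this assay, so the expected step that the limit leaves unreadable from compound 3 to compound 4 is nil. Compound 4 is expected to give 30000 nM in this assay, within a range from 12000 nM to 80000 nM, most probably again reported only as a limit.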

Compound 4, half-maximal inhibitory concentration: > 25000 nM
Compound 4: no number, only a limit; the forecaster's own chance of this, stated with the estimate: 80%; the middle value does not contradict the limit.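

No step can be read from compound 3 to compound 4 or from compound 1 to compound 4 in this assay, since all of these compounds give only a limit: the limit of > 25000 nM in this assay, at which 4 of the 4 values shown sit.

The compounds shown leave open whether either change, hydrogen in place of chloro or 5-methyl-1,3,4-thiadiazol-2-yl in place of 5-methyl-1,3,4-oxadiazol-2-yl, shifts cytotoxicity at all.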